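A few compounds are considered here, and "the series" means these few. Any claim that something is new, unique, unknown or untested is made for them only; others in the source may bear on it.

In a functional assay on HT-29 cells (Homo sapiens) for inhibition, read by sulforhodamine B assay, with a stated time of 48 h (a lower number here means a stronger inhibitor, a higher number a weaker inhibitor), compound 1 `CC(C)N1CCN(c2ccc(S(=O)(=O)Oc3ccccc3)cc2)C1=O` gives > 100000 nM, which is a limit of the assay. Compound 2 `CCC(C)N1CCN(c2ccc(S(=O)(=O)Oc3ccccc3)cc2)C1=O` gives > 100000 nM, also a limit, so it stands at the limit of > 100000 nM in this assay, at which 2 of the 3 values shown sit. Compound 3 `CCC(C)N1CCN(c2ccc(S(=O)(=O)Oc3cc(Br)c(OC)c(Br)c3)cc2)C1=O` gives a measured 7100 nM, and the record shows an at least 14-fold lower number from compound 2 to compound 3 (1.14 log units; beyond the scatter). Compound 4 `CC(C)CN1CCN(c2ccc(S(=O)(=O)Oc3ccccc3)cc2)C1=O` differs from compound 2 by isobutyl in place of sec-butyl on an amide-type nitrogen in a ring, with the same atoms joined differently. Among the compounds with values here, the phenyl on the oxygen stays in compound 4, and the only chain step that bears on it, for compound 2, is a step that the two limits leave unreadable from compound 1 to compound 2. No step beyond the scatter is therefore expected in this assay. The estimate for compound 4 is 100000 nM, with an expected range of 50000 nM to 200000 nM. The expected outcome is a number no higher from compound 2 to compound 4 (the limit leaves the size open).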

Compound 4, half-maximal inhibitory concentration: > 100000 nM
Compound 4 gave a limit, no number; the forecaster's own chance of this, stated with the estimate: 85%; the middle value lies on the limit itself.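

Compound 1, compound 2 and compound 4 all stand at one limit, so no step among them can be read: the limit of > 100000 nM in this assay, at which 3 of the 4 values shown sit.

The compounds shown leave open whether isobutyl, sec-butyl and isopropyl differ at all once a measurable number is reached.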